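Configuration changes in a bis-acyl series: expected outcome

A few compounds are considered here, and "the series" means these few. Any claim that something is new, unique, unknown or untested is made for them only; others in the source may bear on it.

Measured compounds in a functional assay on PC-3 cells (Homo sapiens) for cytotoxicity, read by MTT assay, with a stated time of 48 h, tested at 5 uM; on this read-out lower numbers stand for a weaker effect and higher numbers for a stronger effect at the one concentration tested:
compound 1 `O=C(c1ccc(O)cc1O)[C@@H]1[C@H](C(=O)c2ccc(O)cc2O)[C@@H](c2ccccc2)[C@H]1c1ccccc1` gives 27.1%
compound 2 `O=C(c1ccc(O)cc1O)[C@H]1Cc2ccccc2[C@@H](C(=O)c2ccc(O)cc2O)[C@H]1c1ccccc1` gives 46.1%
compound 3 `O=C(c1ccc(O)cc1O)[C@@H]1Cc2ccccc2[C@H](C(=O)c2ccc(O)cc2O)[C@@H]1c1ccccc1` gives 22.3%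

Compound 1 lies within the scatter of compound 3 and beyond it against compound 2, which gives the highest number of the three in this assay.

Compound 4 `O=C(c1ccc(O)cc1O)[C@@H]1[C@@H](C(=O)c2ccc(O)cc2O)[C@H](c2ccccc2)[C@H]1c1ccccc1` has the same atoms and bonds as compound 1: the two compounds have the same atoms and bonds and differ only in configuration as drawn: 2 of 4 stereo elements differ; a stereocentre at a saturated ring carbon is drawn R in compound 1 and S in compound 4; a stereocentre at a saturated ring carbon is drawn S in compound 1 and R in compound 4. Among the measured compounds shown here, the one measured step that bears on a change of configuration alone is a number 23.8 percentage points lower from compound 2 to compound 3 (beyond the scatter), resting on (the fact that compounds 2 and 3 differ only in the configuration as drawn); it shows configuration can shift the number modestly, but that step inverts all centres, whereas two of four are inverted here, so no direction can be read across. Compound 4 is therefore expected near compound 1, with a number 2.9 percentage points higher from compound 1 to compound 4 (within the scatter) expected to stay inside the scatter. The estimate for compound 4 is 30%, within 12% to 52%.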

Compound 4, a percentage reported as activity, at one concentration (the size of the read-out at that concentration, not a potency): 41.2%
For compound 4 the middle estimate is 11.2 percentage points below the measured one; low and high end bracket the measured number.
By their numbers in this assay, from the lowest: compounds 3 and 1 (each within the scatter of the next); then compounds 4 and 2 (each within the scatter of the next).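

In this assay, inverting two of the four stereocentres gives a number 14.1 percentage points higher from compound 1 to compound 4 (beyond the scatter). A partial change of configuration is therefore enough for a step beyond the scatter, whereas the earlier configuration step involved inversion of all centres. With nothing entering or leaving, this step rests on configuration alone: the fact that compounds 1 and 4 differ only in the configuration as drawn

Which of the two inverted centres carries the step remains open, as does whether either would do so alone. Also open, as far as these compounds go, is how an amine or a carboxylic acid in place of a hydroxyl group would read on either configuration.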